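Swapping methoxy for cyano in compound 2

A few compounds are considered here, and "the series" means these few. Any claim that something is new, unique, unknown or untested is made for them only; others in the source may bear on it.

Three related compounds have numbers in a functional assay on A549 cells (Homo sapiens) for antiproliferative activity, read by MTT assay, with a stated time of 72 h; a higher number here means a weaker inhibitor, a lower number a stronger inhibitor. Compound 1 `C/C=C/C(=O)Nc1cccc(Oc2nc(Nc3cccc(OC)c3)nc3c2CSCC3)c1` gives 21100 nM, compound 2 `COc1cccc(Nc2nc3c(c(Oc4cccc(NC(=O)/C=C/C(C)C)c4)n2)CSCC3)c1` gives 25300 nM and compound 3 `C=C(F)C(=O)Nc1cccc(Oc2nc(Nc3cccc(OC)c3)nc3c2CSCC3)c1` gives 29600 nM. These values all lie within the usual scatter of one another, so compound 2 holds no distinct rank among them.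

Compound 4 `CC(C)/C=C/C(=O)Nc1cccc(Oc2nc(Nc3cccc(C#N)c3)nc3c2CSCC3)c1` keeps the 3-methylbut-1-en-1-yl group of compound 2 on the carbonyl carbon and alters a different part of the molecule: cyano in place of methoxy on an aromatic carbon. The 3-methoxyphenyl group thus becomes 3-cyanophenyl.

Three measured steps are available: a 1.2-fold higher number from compound 1 to compound 2 (0.08 log units; within the scatter), a 1.4-fold higher number from compound 1 to compound 3 (0.15 log units; within the scatter) and a 1.2-fold higher number from compound 2 to compound 3 (0.07 log units; within the scatter). Each one exchanges the group on the carbonyl carbon while methoxy stays in place, and each stays within the scatter. None of them tests the new swap, so they offer only indirect guidance. For the measured compounds named here, no measured compound carries cyano, and the data give no direction for this change. The expected result in this assay is therefore no shift beyond the scatter, with the estimated step being a 1.0-fold lower number from compound 2 to compound 4 (0.01 log units; within the scatter). The estimate for compound 4 is 25000 nM, with an expected range from 9000 nM to 60000 nM.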

Compound 4, half-maximal inhibitory concentration: 35900 nM
The estimate for compound 4 lay 1.4-fold (0.16 log units) below the measured number; the range from low to high includes it.
By their numbers in this assay, from the lowest: compounds 1, 2, 3 and 4 (each within the scatter of the next).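

The swap of methoxy for cyano, on an aromatic carbon meta to a large group, now has a direct reading in this assay: it gives a 1.4-fold higher number from compound 2 to compound 4 (0.15 log units; within the scatter). For the compounds shown here, the earlier steps changed only the group on the carbonyl carbon, so this pair is the first to test a different part of the molecule, and it shows that this exchange, between two groups of equal heavy-atom count, leaves the number within the scatter. No measurement shown here offers an explanation for this result.

As far as these compounds go, this reading rests on a single pair carrying 3-methylbut-1-en-1-yl on the carbonyl carbon, so it remains open whether cyano would behave the same way alongside prop-1-en-1-yl or 1-fluoroethenyl. From the compounds shown here alone, it is also open how another group at this place, such as an amine, a carboxylic acid or a longer chain like butoxy, would read, and whether any change here can move the number beyond the scatter.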